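This account rests on a few compounds, and the source may have more. Where it says the series, first, only, none or still open, it means among the compounds named here.

Of the compounds shown here, three built on a shared core have been measured in an assay on isolated protein for inhibition of high affinity nerve growth factor receptor (Homo sapiens); on this read-out higher numbers stand for weaker inhibition and lower numbers for stronger inhibition. Compound 1 `Cn1cc(/C=C2\C(=O)Nc3ccc(S(N)(=O)=O)cc32)c2ccccc21` gives 4.17 nM in this assay. Compound 2 `NS(=O)(=O)c1ccc2c(c1)/C(=C/c1c[nH]c3ccc(O)cc13)C(=O)N2` gives 5.22 nM. Compound 3 `CN(C)S(=O)(=O)c1ccc2c(c1)/C(=C/c1cn(C)c3ccc(O)cc13)C(=O)N2` gives 9.17 nM, the highest of the three numbers; its nearest neighbour is compound 2, whose number lies within the usual scatter of that of compound 3, while the number of compound 1 lies below it by a margin beyond the scatter.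

Compound 4 `COc1ccc2c(c1)c(/C=C1\C(=O)Nc3ccc(S(=O)(=O)N(C)C)cc31)cn2C` has not yet been measured. It differs from compound 3 in one place: methyl in place of hydrogen on an oxygen on an aromatic ring; the same difference, cut one bond further out, reads hydroxy to methoxy. Among the compounds with values here, no pair of measured compounds shows this change, so no measured step can guide the expectation. Compound 1 carries hydrogen where compound 2 and compound 3 carry hydroxy, but those compounds differ elsewhere too, so only their values can be set side by side. On that basis the step from compound 3 to compound 4 is expected to be small, a 1.6-fold higher number from compound 3 to compound 4 (0.21 log units; within the scatter), leaning toward a weaker number rather than a stronger one. Compound 4 is accordingly estimated at 15 nM, within a range from 5 nM to 45 nM.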

Compound 4, half-maximal inhibitory concentration: 10.1 nM
Estimate against measurement, compound 4: 1.5-fold (0.17 log units) above; measured number inside the range.
By their numbers in this assay, from the lowest: compounds 1, 2, 3 and 4 (each within the scatter of the next, the first and the last beyond it).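

Read in this assay, this pair gives the first direct view of methyl in place of hydrogen on an oxygen on an aromatic ring, a change that can be read only here as a 1.1-fold higher number from compound 3 to compound 4 (0.04 log units; within the scatter). Hydroxy and methoxy therefore cannot be told apart at this place on the background of compound 3, so the hydrogen on that oxygen is not required to keep the number in the range of compound 3. No measurement at hand offers a reason for this result.

The compounds shown leave open whether a larger group on that oxygen, such as a longer chain, or a different group at this place, such as an amine or a carboxylic acid, would stay within the scatter as well. They also leave open whether hydroxy to methoxy would give the same small step on the background of compound 2, which differs from compound 3 in more than one place.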